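Furan-2-yl in Place of a Chlorinated Nitrophenyl Arm

This account rests on a few compounds, and the source may have more. Where it says the series, first, only, none or still open, it means among the compounds named here.

Compound 3 `CC(C)Cc1ccc(C(C)c2nnc3sc(-c4ccc([N+](=O)[O-])cc4Cl)nn23)cc1` gives the highest of the three numbers in a functional assay on the whole organism (strain Wistar albino) for inhibition, with Rattus norvegicus as the target, read by paw edema, with stated times of 30 min and 2 h, at a dose of 20 mg/kg by the oral route (a higher number here means more inhibition at the dose given (going by the name of the read-out), a lower number less inhibition), namely 67%. Compound 2 `CC(C)Cc1ccc(C(C)c2nnc3sc(-c4ccc(Br)cc4)nn23)cc1` gives 64%, and the step of a number 3 percentage points higher from compound 2 to compound 3 (within the scatter) stays within the scatter. Compound 1 `CCCc1nn2c(C(C)c3ccc(CC(C)C)cc3)nnc2s1` gives 28%, so the steps of a number 36 percentage points higher from compound 1 to compound 2 (beyond the scatter) and a number 39 percentage points higher from compound 1 to compound 3 (beyond the scatter) are large. Compound 4 `CC(C)Cc1ccc(C(C)c2nnc3sc(-c4ccco4)nn23)cc1` differs from compound 3 in one place: furan-2-yl in place of 2-chloro-4-nitrophenyl on an aromatic carbon. The two large steps show that an aromatic ring on this carbon, in place of propyl, raises the number; the small step between compound 2 and compound 3 shows that exchanging one such ring for another changes little. Since furan-2-yl is again an aromatic ring, the expected step of a number 9 percentage points lower from compound 3 to compound 4 (within the scatter) is small. Compound 4 is therefore estimated at 58%, within 42% to 72%.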

Compound 4, a percentage reported as inhibition, in the whole organism at one dose (the size of the read-out at that dose, not a potency): 59%
The estimate for compound 4 lay 1 percentage points below the measured number; measured number inside the range.
By their numbers in this assay, from the lowest: compound 1; then compounds 4, 2 and 3 (each within the scatter of the next).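

In this assay a five-membered aromatic ring with 1 hetero atom serves this carbon as well as the six-membered rings do: a number 8 percentage points lower from compound 3 to compound 4 (within the scatter) and a number 5 percentage points lower from compound 2 to compound 4 (within the scatter) both stay within the scatter, while a number 31 percentage points higher from compound 1 to compound 4 (beyond the scatter) is large. Among these compounds, then, the gain over propyl requires neither a six-membered aromatic ring of carbon only nor a chlorine, nitro or bromine substituent. Nothing available explains this result. On these data alone, whether a saturated ring such as cyclohexyl, an amine or a carboxylic acid on this carbon would keep the number remains open. So does whether a chain longer than propyl would raise it.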